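The source may hold more compounds than are shown below. What is called first, only, known or untested is meant among the compounds shown, and "the series" means these compounds.

Measured compounds:
compound 1 `COc1cc(-c2nc3cc(/C=C4\SC(=O)NC4=O)ccc3[nH]2)cc(OC)c1OC`: 13600 nM
compound 2 `COc1cc(OC)c(-c2nc3cc(/C=C4\SC(=O)NC4=O)ccc3[nH]2)cc1OC`: 15300 nM
compound 3 `COc1cc(OC)c(-c2nc3cc(/C=C4\SC(=O)N(CC(=O)N5CCOCC5)C4=O)ccc3[nH]2)cc1OC`: 35700 nM

In an ADME assay on HEK-293T cells (Homo sapiens) for inhibition, read by MTT assay, with a stated time of 48 h (on this read-out lower numbers stand for stronger inhibition and higher numbers for weaker inhibition), compound 1 gives 13600 nM, the lowest of the three numbers, though compound 2 lies within the scatter of it and only compound 3 lies beyond. Compound 4 `COc1cc(-c2nc3cc(/C=C4\SC(=O)N(Cc5cccc(C)c5)C4=O)ccc3[nH]2)cc(OC)c1OC` differs from compound 1 by 3-methylbenzyl in place of hydrogen on an amide-type nitrogen in a ring. For the measured compounds named here, one measured step bears on this change, namely a 2.3-fold higher number from compound 2 to compound 3 (0.37 log units; beyond the scatter), which put a different group on the same ring nitrogen and weakened inhibition modestly. The group entering compound 4 has not been tested, so the size of its effect rests on that single analogy. For compound 4 a modest rise is therefore expected, a 1.6-fold higher number from compound 1 to compound 4 (0.21 log units; within the scatter). Compound 4 is estimated at 22000 nM, with a range from 9000 nM to 50000 nM.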

Compound 4, half-maximal inhibitory concentration: 18900 nM
Compound 4: the middle estimate sits 1.2-fold (0.07 log units) above what was measured, within the range that was stated.
By their numbers in this assay, from the lowest: compounds 1, 2, 4 and 3 (each within the scatter of the next, the first and the last beyond it).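

In this assay, for the compounds shown here, placing 3-methylbenzyl on the amide-type nitrogen gives a 1.4-fold higher number from compound 1 to compound 4 (0.14 log units; within the scatter), whereas the only earlier step at this nitrogen, with a different group and on a different core, is a 2.3-fold higher number from compound 2 to compound 3 (0.37 log units; beyond the scatter). Filling this position therefore need not move the number beyond the scatter, at least for this group on the core of compound 1. Nothing available gives a reason for this result. Still open, going by these compounds, is how a plain benzyl, a chain ending in an amine or a carboxylic acid would behave on this nitrogen. Also open, on these data alone, is whether 3-methylbenzyl would give a similar step on the core of compound 2.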